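The source may report more compounds than this note shows. Statements on the series, on what has been measured and on what is new or still open speak of the compounds shown alone.

Measured so far:
Compound 1 `O=C(Nc1ccc(-c2cscn2)cc1)C1CCCN(Cc2cccnc2)C1`: > 20000 nM
Compound 2 `O=C(Nc1ccc(-c2ccccc2)cc1)C1CCCN(Cc2ccc(F)c(F)c2)C1`: 2580 nM

For the measured compounds named here, in a functional assay on A-375 cells (Homo sapiens) for antiproliferative activity (a higher number here means a weaker inhibitor, a lower number a stronger inhibitor), compound 2 gives 2580 nM, the only actual number in this small set. Compound 1 has no phenyl on the aromatic ring that carries this group in compound 2. Compound 1 gives > 20000 nM, which is a limit of the assay, not a number.

The next compound is compound 3 `O=C(Nc1ccc(-c2ccn[nH]2)cc1)C1CCCN(Cc2ccc(F)c(F)c2)C1`, where 1H-pyrazol-5-yl takes the place of phenyl on an aromatic carbon, para to a large group: 1H-pyrazol-5-yl in place of phenyl on an aromatic carbon. Going by the values given here, no measured pair isolates this change, and compound 1 also differs elsewhere, so the support is thin. A moderate shift towards weaker inhibition in this assay is nevertheless expected. The expected size is a 2.3-fold higher number from compound 2 to compound 3 (0.37 log units; beyond the scatter). For compound 3 the estimated value is 6000 nM, with an expected range of 1800 nM to 20000 nM.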

Compound 3, half-maximal inhibitory concentration: 520 nM
Beside the measured number, compound 3's estimate is 12-fold (1.06 log units) above it, and the stated range ends above it.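

Replacing phenyl with 1H-pyrazol-5-yl on this aromatic carbon, para to a large group, gives a 5.0-fold lower number from compound 2 to compound 3 (0.70 log units; beyond the scatter) in this assay, so activity here does not depend on a six-membered aromatic ring of carbon only. For the compounds shown here, this is the first comparison in the set that differs in one place, and it favours the five-membered aromatic ring with 2 hetero atoms over phenyl. Compound 1 adds nothing to this comparison, as it differs in more than one place and its value is a limit of the assay, not a number: the limit of > 20000 nM in this assay, at which 1 of the 3 values shown sits.

A single swap cannot separate the ring size, the ring nitrogens and the hydrogen-bond donor, which all change together. On these data alone, it remains open whether an imidazole, or a pyrazole with a methyl group on its ring nitrogen, would hold this activity at the same position.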